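Swapping an aryl group for a tert-butoxycarbonyl on the piperazine

The source may report more compounds than this note shows. Statements on the series, on what has been measured and on what is new or still open speak of the compounds shown alone.

Compound 1 `Fc1cccc(COc2ccc(-c3cc(CN4CCN(Cc5ccc(C(F)(F)F)cc5)CC4)no3)cc2)c1`: 2900 nM
Compound 2 `N#Cc1cccc(COc2ccc(-c3cc(CN4CCN(c5ccc(C(F)(F)F)cn5)CC4)no3)cc2)c1`: 1300 nM

In a functional assay on Mahlavu cells (Homo sapiens) for antiproliferative activity, read by sulforhodamine B assay, with a stated time of 72 h (on this read-out higher numbers stand for weaker inhibition and lower numbers for stronger inhibition), compound 2 gives the lowest of the two numbers, and compound 1 gives a number beyond the scatter above it. Compound 3 `CC(C)(C)OC(=O)N1CCN(Cc2cc(-c3ccc(OCc4cccc(C#N)c4)cc3)on2)CC1` differs from compound 2 by one change: tert-butoxycarbonyl in place of 5-(trifluoromethyl)pyridin-2-yl on an amine nitrogen in a ring. Going by the values given here, no measured pair shows this kind of change, so the expected step rests on judgement alone. The step from compound 2 to compound 3 is expected to weaken inhibition, as a 3.1-fold higher number from compound 2 to compound 3 (0.49 log units; beyond the scatter). Compound 3 is therefore estimated at 4000 nM, with a range from 1200 nM to 13000 nM.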

Compound 3, half-maximal inhibitory concentration: 5600 nM
Estimate against measurement, compound 3: 1.4-fold (0.15 log units) below; the range from low to high includes it.
By their numbers in this assay, from the lowest: compound 2; then compounds 1 and 3 (each within the scatter of the next).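

Going by these compounds alone, this is the first comparison in the set that differs in one place: in this assay, tert-butoxycarbonyl in place of 5-(trifluoromethyl)pyridin-2-yl on the amine nitrogen in the ring gives a 4.3-fold higher number from compound 2 to compound 3 (0.63 log units; beyond the scatter). The position therefore responds to what it carries, yet compound 3, which has no ring in this group, still gives a measured 5600 nM. No measurement here explains the step.

These compounds cannot separate the loss of the aromatic ring from the arrival of the carbonyl. An acetyl group or a plain phenyl on the same nitrogen would help to tell these apart.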